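Benzofuranyl for thienyl on the core of compound 1

This account rests on a few compounds, and the source may have more. Where it says the series, first, only, none or still open, it means among the compounds named here.

Measured so far:
compound 1 `Nc1nc(N)c2c(-c3ccsc3)cn([C@@H]3O[C@H](CO)[C@@H](O)[C@H]3O)c2n1` — > 20000 nM
compound 2 `COc1nc(N)nc2c1c(-c1ccsc1)cn2[C@@H]1O[C@H](CO)[C@@H](O)[C@H]1O` — > 20000 nM
compound 3 `Cc1nc(N)c2c(-c3ccsc3)cn([C@@H]3O[C@H](CO)[C@@H](O)[C@H]3O)c2n1` — > 20000 nM

In a functional assay on CCRF-CEM cells (Homo sapiens), read by MTT assay, with a stated time of 72 h (on this read-out higher numbers stand for weaker inhibition and lower numbers for stronger inhibition), compound 1 gives > 20000 nM, a limit of the assay and not a number. Compound 2 likewise gives > 20000 nM, a limit. Compound 3 gives > 20000 nM, also a limit. Hence the two measured steps, a step that the two limits leave unreadable from compound 1 to compound 2 and a step that the two limits leave unreadable from compound 1 to compound 3, cannot be read, since (the limit of > 20000 nM in this assay, at which 3 of the 3 values shown sit). Both alter the group on the other aromatic carbon of the core, not the position changed here.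

Compound 4 `Nc1nc(N)c2c(-c3cc4ccccc4o3)cn([C@@H]3O[C@H](CO)[C@@H](O)[C@H]3O)c2n1` is yet to be measured. It differs from compound 1 by 1-benzofuran-2-yl in place of thiophen-3-yl on an aromatic carbon. Among the compounds with values here, no measured step bears on this position, and no measured compound lies below the limit, so there is no basis for expecting a step beyond the scatter in either direction. Compound 4 is therefore expected to sit near the limit as well, with an estimated value of 20000 nM and a range from 3000 nM to 60000 nM. The expected step from compound 1 is a number no higher from compound 1 to compound 4 (the limit leaves the size open), most likely again reported only as a limit.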

Compound 4, half-maximal inhibitory concentration: > 20000 nM
Compound 4 was reported as a limit (the forecaster's own chance of this, stated with the estimate: 65%); the middle value lies on the limit itself.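

The step from compound 1 to compound 4 cannot be read, since both compounds are reported only as limits: the limit of > 20000 nM in this assay, at which 4 of the 4 values shown sit. The compounds shown leave open whether any of these changes on the shared core alters activity, and by how much.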